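Cyclopentylmethoxy to butoxy on the shared core

The compounds below may be only part of what the source reports. "The series", "measured", "known", "first", "only" and "open" are said of these compounds alone.

For the measured compounds named here, in a functional assay on NUGC-3 cells (Homo sapiens) for antiproliferative activity, read by sulforhodamine B assay (a higher number here means a weaker inhibitor of growth, a lower number a stronger inhibitor of growth), compound 3 (`O=C(/C=C/c1ccc(O)cc1)c1c(O)cccc1OCC1CCCC1`) gives 2140 nM, the only actual number so far. Compound 1 (`CCCCCCOc1cccc(O)c1C(=O)/C=C/c1ccc(O)cc1`) reads > 30000 nM, which is a limit of the assay. Compound 2 (`O=C(/C=C/c1ccc(O)cc1)c1c(O)cccc1OCCC1CCCCC1`) reads > 30000 nM, which is also a limit.

The next structure is compound 4 (`CCCCOc1cccc(O)c1C(=O)/C=C/c1ccc(O)cc1`), and the change to it is propyl in place of cyclopentyl on a saturated chain carbon bound to an oxygen on an aromatic ring. Cut one bond further out, this reads cyclopentylmethoxy to butoxy.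

Going by the values given here, two measured steps bear on this change. One is an at least 14-fold lower number from compound 1 to compound 3 (1.14 log units; beyond the scatter), with cyclopentyl in place of pentyl. The other is an at least 14-fold lower number from compound 2 to compound 3 (1.14 log units; beyond the scatter), with cyclopentyl in place of cyclohexylmethyl. Both end on the cyclopentyl group that compound 4 gives up, while a step that the two limits leave unreadable from compound 1 to compound 2 adds nothing usable. A move to a higher number in this assay is therefore expected, with the estimated step being a 3.7-fold higher number from compound 3 to compound 4 (0.57 log units; beyond the scatter). A result reported only as a limit remains possible. For compound 4 the estimated value is 8000 nM, with an expected range of 2000 nM to 30000 nM.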

Compound 4, concentration for 50% growth inhibition: > 30000 nM
Compound 4: a limit, no number; the forecaster's own chance of this, stated with the estimate: 35%; at least 3.7-fold (0.57 log units) between middle value and limit.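

Compound 4 reads > 30000 nM, which is a limit of the assay. In this assay, cyclopentylmethoxy to butoxy gives an at least 14-fold higher number from compound 3 to compound 4 (1.14 log units; beyond the scatter), so the earlier loss on moving to the groups of compound 1 and compound 2 now has a counterpart in an open chain with fewer carbons than the cyclopentyl group, and among these four compounds a number appears only with cyclopentylmethoxy. The steps among compound 1, compound 2 and compound 4 cannot be read: the limit of > 30000 nM in this assay, at which 3 of the 4 values shown sit.

As far as these compounds go, the full size of the step to compound 4 stays open, since only its lower bound can be read. Also open, from the compounds shown here alone, is whether the ring itself carries the effect: cyclobutylmethoxy, cyclohexylmethoxy or a branched chain such as isobutoxy on the shared core would test this.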